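Hydroxyl on the phenylethyl sulfide: a new analogue

The source may hold more compounds than are shown below. What is called first, only, known or untested is meant among the compounds shown, and "the series" means these compounds.

Three analogues sharing one core have been measured in an assay on isolated protein for inhibition of retinal dehydrogenase 2 (Homo sapiens); on this read-out higher numbers stand for weaker inhibition and lower numbers for stronger inhibition. Compound 1 `CC(Sc1nc2c(cnn2C)c(=O)n1-c1ccc(CO)cc1)c1ccccc1` gives 600 nM. Compound 3 `Cn1ncc2c(=O)n(-c3ccccc3)c(OCc3cccc(F)c3)nc21` gives 3700 nM. Compound 2 `C[C@@H](Sc1nc2c(cnn2C)c(=O)n1-c1ccccc1)c1ccccc1` gives 40 nM, the lowest of the three numbers and the strongest inhibition, its gap to compound 1 and its gap to compound 3 both lying beyond the scatter.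

Compound 4 `CC(Sc1nc2c(cnn2C)c(=O)n1-c1ccccc1)c1cccc(O)c1` differs from compound 2 in one place: a group of 9 heavy atoms (8 carbon, 1 oxygen; one six-membered aromatic ring of carbon only) in place of a group of 8 heavy atoms (8 carbon; one six-membered aromatic ring of carbon only), on a sulfur. The incoming group carries one hydrogen-bond donor and one hydrogen-bond acceptor where the outgoing one carried none, and the defined stereocentre of compound 2 is not specified in compound 4. Going by the values given here, no measured pair shows what such a change does on this core, so the step is expected to be small, most likely toward a somewhat higher number, and possibly not beyond the scatter. For compound 4 in this assay the estimate is 100 nM, with a range from 30 nM to 400 nM. The step from compound 2 to compound 4 is thus expected to be a 2.5-fold higher number from compound 2 to compound 4 (0.40 log units; beyond the scatter).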

Compound 4, half-maximal inhibitory concentration: 100 nM
The estimate for compound 4 equals the measured number at the digits printed; the range from low to high includes it.
By their numbers in this assay, from the lowest: compound 2; then compound 4; then compound 1; then compound 3.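

In this assay, the step from the 1-phenylethyl group to its hydroxyl-bearing counterpart on the sulfur gives a 2.5-fold higher number from compound 2 to compound 4 (0.40 log units; beyond the scatter) and so shows that this position accepts the added hydroxyl with only a modest loss of inhibition. The step joins two changes, since compound 2 has a defined stereocentre and compound 4 has none specified, and the share of each cannot be separated. Nothing at hand explains the size of the step.

As far as these compounds go, it remains open how the two separate stereoisomers of compound 4 would compare with each other and with compound 2. From the compounds shown here alone, it is also open whether the hydroxyl's hydrogen matters, which a methoxy group or an amine in its place on the same ring would test.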